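Acyl and hydrazone aryl swaps in a thiazole series

A few compounds are considered here, and "the series" means these few. Any claim that something is new, unique, unknown or untested is made for them only; others in the source may bear on it.

Working notes. In a functional assay on A549 cells (Homo sapiens) for inhibition, read by MTT assay, with a stated time of 72 h (on this read-out lower numbers stand for stronger inhibition and higher numbers for weaker inhibition), compound 1 `CN(C(=O)NC(=O)c1cccc(C(F)(F)F)c1)c1nc(C(F)(F)F)c(C(=O)N/N=C/c2ccc(C(F)(F)F)cc2)s1` gives 6.2 ug/mL. Within the data shown here, compound 2 `CN(C(=O)NC(=O)c1ccc(C(F)(F)F)cc1)c1nc(C(F)(F)F)c(C(=O)N/N=C/c2ccc(C(F)(F)F)cc2)s1` carries the change 4-(trifluoromethyl)phenyl in place of 3-(trifluoromethyl)phenyl on a carbonyl carbon and reaches only the limit of this assay, > 100 ug/mL; the step is an at least 16-fold higher number from compound 1 to compound 2 (1.20 log units; beyond the scatter), with the limit of > 100 ug/mL in this assay, at which 1 of the 3 values shown sits, as the only supporting evidence. Compound 3 `CN(C(=O)NC(=O)c1ccccc1F)c1nc(C(F)(F)F)c(C(=O)N/N=C/c2cccc(C(F)(F)F)c2)s1` gives 19.5 ug/mL in this assay; the difference between its core and that of compound 1 is not broken down here. Compound 4 `CN(C(=O)NC(=O)c1ccccc1F)c1nc(C(F)(F)F)c(C(=O)N/N=C/c2ccc(C(F)(F)F)cc2)s1` is unmeasured and differs from compound 3 by 4-(trifluoromethyl)phenyl in place of 3-(trifluoromethyl)phenyl on a carbon with a double bond to nitrogen. This is the same kind of change as from compound 1 to compound 2, not the same: there it sat on a carbonyl carbon whose other neighbour is an amide-type nitrogen, here on a carbon double-bonded to nitrogen. The expected step is a 1.8-fold higher number from compound 3 to compound 4 (0.25 log units; within the scatter), resting on the loss recorded as an at least 16-fold higher number from compound 1 to compound 2 (1.20 log units; beyond the scatter), tempered by the different place. Compound 4 is expected at 35 ug/mL, within 12 ug/mL to 100 ug/mL.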

Compound 4, half-maximal inhibitory concentration: 5.68 ug/mL
Estimate against measurement, compound 4: 6.2-fold (0.79 log units) above; measured number below the stated range.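

With 4-(trifluoromethyl)phenyl in place of 3-(trifluoromethyl)phenyl on a carbon with a double bond to nitrogen, the result is a 3.4-fold lower number from compound 3 to compound 4 (0.54 log units; beyond the scatter), so the change does not carry over from the carbonyl carbon in direction or size: the same change on two cores in this assay, an at least 16-fold higher number (1.20 log units; beyond the scatter) from compound 1 to compound 2 and a 3.4-fold lower number (0.54 log units; beyond the scatter) from compound 3 to compound 4, at least 55-fold (1.74 log units) apart, beyond the scatter of two such steps. In this assay compound 2 gives > 100 ug/mL, which is a limit and not a number. The two steps differ in both place and partner aryl group, and these are not separated here, while 2-fluorophenyl on the carbonyl carbon gives an at least 17-fold lower number from compound 2 to compound 4 (1.24 log units; beyond the scatter) and a 1.1-fold lower number from compound 1 to compound 4 (0.04 log units; within the scatter).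

From the compounds shown here alone, whether the hydrazone aryl swap runs the same way with 3-(trifluoromethyl)phenyl on the carbonyl carbon stays open. So does the effect of an amine or a carboxylic acid on either aryl ring.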